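Shifting one hydroxyphenyl and its expected cost in cytotoxicity

This account rests on a few compounds, and the source may have more. Where it says the series, first, only, none or still open, it means among the compounds named here.

Three measured compounds share one core and carry three hydroxyphenyl groups on it. In an ADME assay on HEK293 cells (Homo sapiens) for cytotoxicity, read by CCK-8 assay, with a stated time of 4 days (a higher number here means a weaker inhibitor, a lower number a stronger inhibitor), compound 2 `Oc1cccc(-c2cc(-c3ccccc3O)nc(-c3ccccc3O)c2)c1` gives 80 nM. Compound 3 `Oc1ccccc1-c1cc(-c2ccccc2O)nc(-c2ccccc2O)c1` gives 140 nM in this assay, and compound 1 `Oc1ccc(-c2cc(-c3ccccc3O)cc(-c3cccc(O)c3)n2)cc1` gives 5650 nM. Within the data shown here, compound 3 thus holds the second highest of the three numbers, but the only measured step that reaches it, a 1.8-fold higher number from compound 2 to compound 3 (0.24 log units; within the scatter), lies within the scatter, so compound 2 and compound 3 cannot be told apart; compound 1 sits far higher.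

Compound 4 `Oc1ccc(-c2cc(-c3ccccc3O)cc(-c3ccccc3O)n2)cc1` has not yet been measured in this assay. It is related to compound 3 by a change in one place: 4-hydroxyphenyl in place of 2-hydroxyphenyl on an aromatic carbon. Among the measured compounds shown here, no measured step shows exactly this change. The step from compound 2 to compound 3 swaps a 3-hydroxyphenyl for a 2-hydroxyphenyl and changes little. For the measured compounds named here, compound 1, the only measured compound carrying a 4-hydroxyphenyl, gives a much higher number than compound 3, though it also differs from compound 4 in a second place, so its value is only a hint. Compound 4 is therefore expected to show a rise beyond the scatter, an 8.6-fold higher number from compound 3 to compound 4 (0.93 log units; beyond the scatter). Compound 4 is estimated at 1200 nM, with a range from 250 nM to 6000 nM.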

Compound 4, half-maximal inhibitory concentration: 6990 nM
The estimate for compound 4 lay 5.8-fold (0.77 log units) below the measured number, and the stated range ends below it.
By their numbers in this assay, from the lowest: compounds 2 and 3 (each within the scatter of the next); then compounds 1 and 4 (each within the scatter of the next).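

In this assay, the carbon next to the ring nitrogen proves highly sensitive to which hydroxyphenyl it carries, as 4-hydroxyphenyl in place of 2-hydroxyphenyl there gives a large rise, a 50-fold higher number from compound 3 to compound 4 (1.70 log units; beyond the scatter); before this, the only sign of such an effect came from compound 1, which differs from compound 3 in more than one place. The other exchange, 2-hydroxyphenyl in place of 3-hydroxyphenyl, now reads small a second time, a 1.2-fold higher number from compound 1 to compound 4 (0.09 log units; within the scatter), so compound 1 and compound 4 cannot be told apart, and the high numbers of both go with the 4-hydroxyphenyl next to the ring nitrogen only among the compounds shown. That small exchange also reads alike whichever group stands next to the ring nitrogen: the same change on two cores in this assay, a 1.8-fold higher number (0.24 log units; within the scatter) from compound 2 to compound 3 and a 1.2-fold higher number (0.09 log units; within the scatter) from compound 1 to compound 4, 1.4-fold (0.15 log units) apart, within the scatter of two such steps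

The compounds shown leave open how a 3-hydroxyphenyl next to the ring nitrogen would read, and so whether the rise belongs to the 4-hydroxyphenyl alone or follows any move of the hydroxyl away from the 2-hydroxyphenyl arrangement. They also leave open whether the hydroxyl itself matters at this place, which a methoxy group or an amine on the same phenyl ring could address.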